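Allylsulfanyl at the core position where a larger thioether weakened inhibition

The compounds below may be only part of what the source reports. "The series", "measured", "known", "first", "only" and "open" are said of these compounds alone.

Measured so far:
compound 1, `Cc1cc(N2CC[C@@H](C)[C@@H](N(C)c3ncnc4[nH]ccc34)C2)n2ncnc2n1`: 11300 nM
compound 2, `Cc1cc(N2CC[C@@H](C)[C@@H](N(C)c3ncnc4[nH]ccc34)C2)n2nc(SCc3nc4ccccc4[nH]3)nc2n1`: > 100000 nM

Among the measured compounds shown here, compound 1 is the only compound with a numerical value in a functional assay on HGC-27 cells (Homo sapiens) for inhibition, read by MTT assay, with a stated time of 72 h; a higher number here means a weaker inhibitor, a lower number a stronger inhibitor; its value is 11300 nM. Compound 2 reaches only a limit of this assay, > 100000 nM, as noted in the limit of > 100000 nM in this assay, at which 1 of the 2 values shown sits. The step of an at least 8.8-fold higher number from compound 1 to compound 2 (0.94 log units; beyond the scatter) therefore marks a clear loss of inhibition when ((1H-benzimidazol-2-yl)methyl)sulfanyl replaces hydrogen on the aromatic carbon.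

Compound 3, `C=CCSc1nc2nc(C)cc(N3CC[C@@H](C)[C@@H](N(C)c4ncnc5[nH]ccc45)C3)n2n1`, carries the change (allylsulfanyl in place of hydrogen on an aromatic carbon), at the same aromatic carbon. For the measured compounds named here, the single measured step bearing on it points toward a weaker inhibitor, though the allylsulfanyl group is a smaller substituent than the one in compound 2. Compound 3 is thus expected to show a step of a 3.5-fold higher number from compound 1 to compound 3 (0.55 log units; beyond the scatter), a moderate rise rather than a fall to the limit. The estimate for compound 3 is 40000 nM, with a range from 14000 nM to 120000 nM.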

Compound 3, half-maximal inhibitory concentration: 35200 nM
Compound 3: middle estimate off by 1.1-fold (0.06 log units), on the high side; the measured number falls inside the stated range.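

In this assay, a substituent on this aromatic carbon between two ring nitrogen atoms now has a size of effect that is a number and not a bound: allylsulfanyl gives a 3.1-fold higher number from compound 1 to compound 3 (0.49 log units; beyond the scatter). Within the thioether series, replacing the 1H-benzimidazol-2-yl by vinyl gives an at least 2.8-fold lower number from compound 2 to compound 3 (0.45 log units; beyond the scatter), so the weakening depends on what the sulfur carries and not on the sulfur alone. The size of this second step is open-ended, as the value of compound 2 is a limit and not a number: the limit of > 100000 nM in this assay, at which 1 of the 3 values shown sits.

The compounds shown leave open whether any group at this carbon can lower the number below that of compound 1, since both substituents shown raise it. An amine, a carboxylic acid or a longer chain on the sulfur, or a methoxy group in place of the thioether, could each still move the value either way.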